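Fluorine Position Swap on a Shared Core

The source may hold more compounds than are shown below. What is called first, only, known or untested is meant among the compounds shown, and "the series" means these compounds.

Compound 2 `COc1cc2c(Oc3ccc(NC(=O)c4nn(-c5ccc(F)cc5)c(=O)c5ccccc45)cc3F)ccnc2cc1OCCCN1CCC(C)CC1` holds the lowest of the two numbers measured in a functional assay on MDA-MB-231 cells (Homo sapiens) for cytotoxicity, read by MTT assay, with a stated time of 72 h (a higher number here means a weaker inhibitor, a lower number a stronger inhibitor), where compound 2 gives 660 nM. Compound 1 `COc1cc2c(Oc3ccc(NC(=O)c4nn(-c5ccccc5F)c(=O)c5ccccc45)cc3F)ccnc2cc1OCCCN1CCCC1` gives 950 nM in this assay, a value within the scatter of compound 2. Compound 3 `COc1cc2c(Oc3ccc(NC(=O)c4nn(-c5ccccc5F)c(=O)c5ccccc45)cc3F)ccnc2cc1OCCCN1CCC(C)CC1` is not yet measured; it differs from compound 2 by 2-fluorophenyl in place of 4-fluorophenyl on an aromatic nitrogen. Going by the values given here, no step between measured compounds isolates this change. The step of a 1.2-fold higher number from compound 2 to compound 3 (0.08 log units; within the scatter) is expected to stay within the scatter, because compound 1 with the same 2-fluorophenyl gives 950 nM in this assay. Compound 3 is therefore expected at 800 nM, within 400 nM to 1600 nM.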

Compound 3, half-maximal inhibitory concentration: 670 nM
Estimate against measurement, compound 3: 1.2-fold (0.08 log units) above; the measured number falls inside the stated range.
By their numbers in this assay, from the lowest: compounds 2, 3 and 1 (each within the scatter of the next).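

With 4-methylpiperidin-1-yl held constant, the swap of 4-fluorophenyl for 2-fluorophenyl on the aromatic nitrogen can now be read alone in this assay, and a 1.0-fold higher number from compound 2 to compound 3 (0.01 log units; within the scatter) stays within the scatter. With 2-fluorophenyl held constant, 4-methylpiperidin-1-yl in place of pyrrolidin-1-yl can also be read alone, and a 1.4-fold lower number from compound 1 to compound 3 (0.15 log units; within the scatter) likewise stays within the scatter. No measurement at hand explains either result. The compounds shown leave open whether an unsubstituted phenyl or a pyridine ring on that nitrogen would also stay within the scatter. The same holds for a morpholine or a dimethylamine on the saturated chain carbon.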